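Amino Added to Two Quinolone-Type Cores

The source may report more compounds than this note shows. Statements on the series, on what has been measured and on what is new or still open speak of the compounds shown alone.

Of the compounds shown here, three have been tested in a functional assay on HepG2 cells (Homo sapiens) for cytotoxicity, read by sulforhodamine B assay, with a stated time of 48 h; a higher number here means a weaker inhibitor, a lower number a stronger inhibitor. Compound 1 `CCn1cc(-c2nc3ccccc3[nH]2)c(=O)c2cc(F)c(N3CCNCC3)cc21` and compound 2 `CCn1cc(-c2nc3ccccc3[nH]2)c(=O)c2cc(F)c(N3CCNCC3)nc21` share most of their structure, but the difference between the two cores is not broken down here. Compound 3 `CCn1cc(-c2nc3ccc(N)cc3[nH]2)c(=O)c2cc(F)c(N3CCNCC3)cc21` is compound 1 with an amino group added, the change being (amino in place of hydrogen on an aromatic carbon).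

In this assay compound 2 gives 9100 nM. Compound 1 reaches only a limit of the assay, > 10000 nM. Compound 3 likewise reaches only a limit, > 10000 nM. The step that the two limits leave unreadable from compound 1 to compound 3 therefore cannot be sized, which rests on (the limit of > 10000 nM in this assay, at which 2 of the 3 values shown sit).

Compound 4 `CCn1cc(-c2nc3ccc(N)cc3[nH]2)c(=O)c2cc(F)c(N3CCNCC3)nc21` has not yet been measured. It stands to compound 2 as compound 3 stands to compound 1, the change being (amino in place of hydrogen on an aromatic carbon), the same kind of change made on a core that differs in a way not broken down here.

Since the earlier step gave no readable size, the expected step of a 1.1-fold higher number from compound 2 to compound 4 (0.04 log units; within the scatter) is essentially flat, because compound 2 already sits at 9100 nM. For compound 4 the estimate in this assay is 10000 nM, with a real chance that only a limit is reported.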

Compound 4, half-maximal inhibitory concentration: > 10000 nM
Compound 4 gave a limit, no number; the forecaster's own chance of this, stated with the estimate: 60%; the middle value lies on the limit itself.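

In this assay compound 4 gives > 10000 nM, which is a limit of the assay and not a number. On the core of compound 2, amino in place of hydrogen on an aromatic carbon therefore gives an at least 1.0-fold higher number from compound 2 to compound 4 (0.04 log units; that floor lies within the scatter), a floor rather than a true size, so the change shows no sign of producing a stronger inhibitor on this core, while the real step could be larger. Whether the change has the same size on the two cores cannot be said, because the matching step on the core of compound 1 cannot be read and most of the results give no number to compare: the limit of > 10000 nM in this assay, at which 3 of the 4 values shown sit.

Compound 2 alone gives a number, 9100 nM. As far as these compounds go, how far the other compounds lie past the limit stays open. Also open, from the compounds shown here alone, is whether a different group on that same aromatic carbon, such as a carboxylic acid or a methoxy group, or a longer chain in place of the ethyl, would give a value that can be read in this assay.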